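The source may report more compounds than this note shows. Statements on the series, on what has been measured and on what is new or still open speak of the compounds shown alone.

Measured so far in an ADME assay on L6 cells (Rattus norvegicus) for cytotoxicity; on this read-out lower numbers stand for stronger inhibition and higher numbers for weaker inhibition:
- Compound 1 `COc1c(C(=N)N)cccc1-c1cc(-c2ccc(C(=N)N)cc2)no1`: 52800 nM
- Compound 2 `COc1c(C(=N)N)cccc1-c1cc(-c2ccc(C(=N)N)cc2[N+](=O)[O-])no1`: 116000 nM

Of these two, compound 2 holds the higher number, and compound 1 lies below it. Compound 3 `COc1cc(C(=N)N)ccc1-c1cc(-c2cccc(C(=N)N)c2OC)on1` differs from compound 2 by a single swap: methoxy in place of nitro on an aromatic carbon. Among the compounds with values here, only one measured step bears on this change, and it is a modest one: a 2.2-fold higher number from compound 1 to compound 2 (0.34 log units; beyond the scatter). That step came with nitro in place of hydrogen, and it shows nothing directly about methoxy at this place. With the nitro gone, compound 3 is expected to give back part of that step, so a small move towards a lower number is expected in this assay, perhaps not beyond the scatter. The expected step is a 1.7-fold lower number from compound 2 to compound 3 (0.22 log units; within the scatter). For compound 3 the estimate is 70000 nM, with an expected range from 28000 nM to 170000 nM.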

Compound 3, half-maximal inhibitory concentration: 191000 nM
Estimate against measurement, compound 3: 2.7-fold (0.44 log units) below; measured number outside the range, above it.
By their numbers in this assay, from the lowest: compound 1; then compounds 2 and 3 (each within the scatter of the next).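

Compound 3 shows that the higher number seen with nitro is not confined to that group. Methoxy on this aromatic carbon, ortho to a large group, also stands apart from hydrogen in this assay (a 3.6-fold higher number from compound 1 to compound 3 (0.56 log units; beyond the scatter)), while the swap of nitro for methoxy stays within the scatter (a 1.6-fold higher number from compound 2 to compound 3 (0.22 log units; within the scatter)), so these two groups cannot be told apart here. Both substituted compounds therefore sit above compound 1 on this read-out, though nothing shown accounts for this.

The compounds leave open whether any group on this carbon would give a number above that of compound 1, or only some groups would; an amine, a carboxylic acid or a single fluorine would test this. Going by these compounds, whether a longer chain than methoxy would carry the number further also remains open.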